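This account rests on a few compounds, and the source may have more. Where it says the series, first, only, none or still open, it means among the compounds named here.

Measured so far in a functional assay on CHO cells for agonist activity at Alpha-1B adrenergic receptor (Homo sapiens), read by FLIPR and calcium flux; a lower number here means that less compound is needed, a higher number that more compound is needed for the effect:
compound 1, `Cc1n[nH]cc1-c1cccc2c1CCC2c1ncc[nH]1`, 902 nM
compound 2, `c1ccc(-c2cccc3c2CCC3c2ncc[nH]2)nc1`, > 10000 nM

In this assay compound 1 gives 902 nM. For compound 2 this assay reports only a limit, > 10000 nM, not a number. Compound 2 therefore stands at the upper edge of the numbers shown, at the limit of > 10000 nM in this assay, at which 1 of the 2 values shown sits. The step of an at least 11-fold higher number from compound 1 to compound 2 (1.04 log units; beyond the scatter) gives only the lower bound of that loss.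

Compound 3, `COc1cccc2c1CCC2c1ncc[nH]1`, differs from compound 2 in one place: methoxy in place of pyridin-2-yl on an aromatic carbon. Within the data shown here, the only measured step bearing on this position is an at least 11-fold higher number from compound 1 to compound 2 (1.04 log units; beyond the scatter); it shows that this position is sensitive, but it compares two aromatic rings, neither of which is methoxy, so it fixes no direction for the present change. With compound 2 at a limit, the step of an at least 1.4-fold lower number from compound 2 to compound 3 (0.15 log units; that floor lies within the scatter) is expected to be modest and poorly anchored. Compound 3 is estimated at 7000 nM, in the range 1500 nM to 30000 nM, with a fair chance that this assay again reports only a limit.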

Compound 3, half-maximal effective concentration: > 10000 nM
Compound 3 gave a limit, no number; the forecaster's own chance of this, stated with the estimate: 40%; middle value at least 1.4-fold (0.15 log units) away from the limit.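

In this assay compound 3 also gives only a limit, > 10000 nM, so the step from compound 2 to compound 3 cannot be read. The loss at this aromatic carbon is not confined to pyridin-2-yl: methoxy, a much smaller group with no ring, gives an at least 11-fold higher number from compound 1 to compound 3 (1.04 log units; beyond the scatter). Of the three groups shown at this position, only 3-methyl-1H-pyrazol-4-yl gives a number, and the other two compounds sit at the same ceiling: the limit of > 10000 nM in this assay, at which 2 of the 3 values shown sit.

From the compounds shown here alone, how far compound 2 and compound 3 actually lie beyond that limit remains open, as does which feature of 3-methyl-1H-pyrazol-4-yl goes with the measurable value. A pyrazol-4-yl without the methyl group, or a small amine on the same carbon, would help separate these possibilities.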